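The source may report more compounds than this note shows. Statements on the series, on what has been measured and on what is new or still open speak of the compounds shown alone.

The measured compounds:
compound 1 `Oc1ccc(O)c(COCc2cc(O)cc(Cl)c2O)c1`; in a functional assay on A549 cells (Homo sapiens) for cytotoxicity, read by sulforhodamine B assay (a lower number here means a stronger inhibitor, a higher number a weaker inhibitor), compound 1 gives 18300 nM
compound 2 `Oc1ccc(O)c(COCc2cc(O)ccc2O)c1`; in this assay compound 2 gives 18200 nM
compound 3 `COCc1cc(O)c(Cc2cc(O)ccc2O)cc1O`; in this assay compound 3 gives 33800 nM

Compound 3 has the highest of the three numbers; its nearest neighbour is compound 1, and its gaps to compound 1 and to compound 2 both lie within the scatter, so this assay does not separate the three. Among the measured compounds shown here, the single measured step, a 1.0-fold lower number from compound 1 to compound 2 (0.00 log units; within the scatter), concerns hydrogen in place of chloro on an aromatic carbon and leaves the number within the scatter.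

Compound 4 `COCc1cc(O)c(Cc2cc(O)c(Cc3cc(O)ccc3O)cc2O)cc1O` differs from compound 3 by 2,5-dihydroxybenzyl in place of hydrogen on an aromatic carbon. For the measured compounds named here, no measured step concerns a 2,5-dihydroxybenzyl group entering in place of hydrogen, and the one step that is known describes a different change on a different compound. Going by the values given here, the measured compounds therefore offer no direction for this step, and no step beyond the scatter is expected. Compound 4 is expected to give 25000 nM in this assay, within a range from 8000 nM to 80000 nM. That estimate means an expected step of a 1.4-fold lower number from compound 3 to compound 4 (0.13 log units; within the scatter).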

Compound 4, half-maximal inhibitory concentration: 23500 nM
Estimate against measurement, compound 4: 1.1-fold (0.03 log units) above; low and high end bracket the measured number.
By their numbers in this assay, from the lowest: compounds 2, 1, 4 and 3 (each within the scatter of the next).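

Replacing hydrogen with 2,5-dihydroxybenzyl on this aromatic carbon, ortho to a hydroxy group, gives (a 1.4-fold lower number from compound 3 to compound 4 (0.16 log units; within the scatter)) in this assay. The position therefore carries this added group, with its six-membered aromatic ring, without a step that this assay can separate from the scatter. The only earlier step concerned chloro and hydrogen on a different compound, so this is the sole reading for this position, and no measurement shown accounts for it.

As far as these compounds go, whether an amine, a carboxylic acid or a simple methyl group on the same carbon would move the number beyond the scatter remains open. Also open, from the compounds shown here alone, is whether the hydroxy groups of the 2,5-dihydroxybenzyl group matter, as a plain benzyl group would test.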